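This account rests on a few compounds, and the source may have more. Where it says the series, first, only, none or still open, it means among the compounds named here.

Three compounds share one core and differ only in a single group on the outer aromatic ring. Compound 1 `COc1cccc(-c2ccc(OC)c(S(=O)(=O)Nc3cccc(NCCNC(=O)c4ccccc4OC)c3)c2)c1` carries a methoxy there and gives 800 nM in an assay on CHO-K1 cells for agonist activity at Orexin receptor type 2 (Homo sapiens), read by a luciferase reporter; on this read-out lower numbers stand for an effect already at smaller amounts and higher numbers for an effect only at larger amounts of compound. Compound 2 `COC(=O)c1cccc(-c2ccc(OC)c(S(=O)(=O)Nc3cccc(NCCNC(=O)c4ccccc4OC)c3)c2)c1` carries a methoxycarbonyl instead, and in this assay compound 2 gives > 10000 nM, which is a limit of the assay and not a number (the limit of > 10000 nM in this assay, at which 1 of the 3 values shown sits). Compound 3 `COc1ccccc1C(=O)NCCNc1cccc(NS(=O)(=O)c2cc(-c3cccc(C(=O)N(C)C)c3)ccc2OC)c1` carries a dimethylcarbamoyl and gives 50 nM in this assay, the lowest of the two numbers shown, with compound 1 as the nearest neighbour. All measured steps are large: a 16-fold lower number from compound 1 to compound 3 (1.20 log units; beyond the scatter), an at least 12-fold higher number from compound 1 to compound 2 (1.09 log units; beyond the scatter) and an at least 200-fold lower number from compound 2 to compound 3 (2.30 log units; beyond the scatter).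

Compound 4 `COc1ccccc1C(=O)NCCNc1cccc(NS(=O)(=O)c2cc(-c3cccc(N)c3)ccc2OC)c1` has not been measured. It differs from compound 3 by amino in place of dimethylcarbamoyl on an aromatic carbon. Within the data shown here, no measured step involves an amino at this position, so the expectation rests on the steps around compound 3. The step of a 16-fold lower number from compound 1 to compound 3 (1.20 log units; beyond the scatter) shows that the dimethylcarbamoyl goes with the lowest number in the set, and compound 4 loses that group entirely. Compound 4 is therefore expected to move to a higher number, a 10-fold higher number from compound 3 to compound 4 (1.00 log units; beyond the scatter) in this assay. The estimate for compound 4 is 500 nM, within a range from 100 nM to 3000 nM.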

Compound 4, half-maximal effective concentration: > 1000 nM
Compound 4: only a limit was reported; the forecaster's own chance of this, stated with the estimate: 10%; at least 2.0-fold (0.30 log units) between middle value and limit.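

For compound 4 the result is a limit of the assay and not a number: the limit of > 1000 nM in this assay, at which 1 of the 4 values shown sits.

Even so, replacing the dimethylcarbamoyl with the much smaller amino gives an at least 20-fold higher number from compound 3 to compound 4 (1.30 log units; beyond the scatter), and this shows that a nitrogen on this aromatic carbon does not by itself keep the low number of compound 3; compound 2 had already shown the same for a carbonyl, so among the four compounds only the complete dimethylcarbamoyl goes with a low number. The comparison with methoxy settles less: it gives an at least 1.2-fold higher number from compound 1 to compound 4 (0.09 log units; that floor lies within the scatter), so amino and methoxy cannot be placed in order at this position, and the step between compound 2 and compound 4 cannot be read, both values being limits.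

Going by these compounds, how far the true value of compound 4 lies beyond its limit remains open. Also open, on these data alone, is how much of the dimethylcarbamoyl is needed, which a primary carboxamide, a methylcarbamoyl or a dimethylamino group at this position could begin to separate.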